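Swapping Butoxy for Butylamino on the Shared Core

The compounds below may be only part of what the source reports. "The series", "measured", "known", "first", "only" and "open" are said of these compounds alone.

Within the data shown here, in an ADME assay on U2OS cells (Homo sapiens) for cytotoxicity (a higher number here means that more compound is tolerated, a lower number that less compound is tolerated), compound 3 `CCCCOc1ccc(C(=O)N/N=C/c2ccc([N+](=O)[O-])o2)cc1` gives 46600 nM, the higher of the two actual numbers so far. The other, from compound 2 `CCCCc1ccc(C(=O)N/N=C/c2ccc([N+](=O)[O-])o2)cc1`, is 19600 nM. Compound 1 `CCCCCCCCc1ccc(C(=O)N/N=C/c2ccc([N+](=O)[O-])o2)cc1` gives > 200000 nM, which is a limit of this assay and not a number.

Compound 4 `CCCCNc1ccc(C(=O)N/N=C/c2ccc([N+](=O)[O-])o2)cc1` keeps the core of compound 3 and carries butylamino in place of butoxy on an aromatic carbon. Among the measured compounds shown here, no measured step makes exactly this swap. The closest guide is the change at the same place, butoxy in place of butyl, which gave a 2.4-fold higher number from compound 2 to compound 3 (0.38 log units; beyond the scatter). The two steps that start from compound 1 are less useful. They involve the long octyl chain and rest on a limit, and they are an at least 10-fold lower number from compound 1 to compound 2 (1.00 log units; beyond the scatter) and an at least 4.2-fold lower number from compound 1 to compound 3 (0.63 log units; beyond the scatter).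

For the measured compounds named here, with compound 2 and compound 3 as the only close pair, a change no larger than that modest step seems likely here, perhaps toward a slightly lower number. The expected change is a 1.6-fold lower number from compound 3 to compound 4 (0.19 log units; within the scatter), which is only an estimate. For compound 4 the estimated value is 30000 nM, with an expected range from 11000 nM to 85000 nM.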

Compound 4, half-maximal cytotoxic concentration: 12000 nM
Compound 4: middle estimate off by 2.5-fold (0.40 log units), on the high side; low and high end bracket the measured number.
By their numbers in this assay, from the lowest: compounds 4 and 2 (each within the scatter of the next); then compound 3. At a limit, above all of these: compound 1.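

In this assay, the atom that joins the four-carbon chain to the aromatic ring clearly matters, since exchanging butoxy for butylamino gives a 3.9-fold lower number from compound 3 to compound 4 (0.59 log units; beyond the scatter); this swap keeps the heavy-atom count and adds a hydrogen-bond donor. The comparison with the plain chain gives a 1.6-fold lower number from compound 2 to compound 4 (0.21 log units; within the scatter), so butylamino and butyl cannot be told apart here, and among compounds 2, 3 and 4 only compound 3, with butoxy, stands apart from the other two. The step away from octyl, an at least 16-fold lower number from compound 1 to compound 4 (1.22 log units; beyond the scatter), starts from a limit and not a number, so it shows only the smallest possible size of the change: the limit of > 200000 nM in this assay, at which 1 of the 4 values shown sits.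

The compounds shown leave open whether the added hydrogen-bond donor is what separates butylamino from butoxy, and a butyl(methyl)amino group, with no hydrogen on its nitrogen, or a butylthio group would test that directly. They also leave open whether the same gap between the oxygen and nitrogen links persists on a longer chain, as octyloxy and octylamino groups would show.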